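A few compounds are considered here, and "the series" means these few. Any claim that something is new, unique, unknown or untested is made for them only; others in the source may bear on it.

Three compounds share one core and differ only in the methoxy pattern of their pendant aryl ring: compound 1 `COc1ccc(-c2cn(-c3ccc(O)c(C(=O)O)c3)nn2)cc1`, compound 2 `COc1ccc(OC)c(-c2cn(-c3ccc(O)c(C(=O)O)c3)nn2)c1` and compound 3 `COc1ccccc1-c1cn(-c2ccc(O)c(C(=O)O)c2)nn1`. In a functional assay on CCRF-CEM cells (Homo sapiens) for inhibition, read by MTT assay, with a stated time of 2 days, tested at 10 uM (on this read-out higher numbers stand for more inhibition at the one concentration tested (going by the name of the read-out) and lower numbers for less inhibition), compound 1 gives 9%, compound 2 gives 9% and compound 3 gives 9%. Going by the values given here, compound 2 thus stands level with compounds 1 and 3, and the one single-point step, hydrogen in place of methoxy on an aromatic carbon, shows no change at the digits printed from compound 2 to compound 3 (within the scatter).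

Compound 4 `COc1ccc(OC)c(-c2cn(-c3ccc(O)c(C(=O)OCCCc4ccccc4)c3)nn2)c1` is not yet measured. It differs from compound 2 by 3-phenylpropyl in place of hydrogen on an oxygen next to a carbonyl group, on an oxygen next to a carbonyl group whose other neighbour is the carbonyl carbon; cut one bond further out, this reads as hydroxy to 3-phenylpropoxy. Among the compounds with values here, no measured step touches this oxygen, so the only guide is that every change so far, as from compound 2 to compound 3, left this assay unmoved. On that basis compound 4 is expected to show a step of a number 1 percentage points higher from compound 2 to compound 4 (within the scatter), that is none beyond the scatter, and its value in this assay is estimated at 10%, with a range from 0% to 35%.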

Compound 4, a percentage reported as inhibition, at one concentration (the size of the read-out at that concentration, not a potency): 5%
Beside the measured number, compound 4's estimate is 5 percentage points above it; the range from low to high includes it.
By their numbers in this assay, from the lowest: compounds 4, 1, 2 and 3 (each within the scatter of the next).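

Going by these compounds alone, the oxygen next to a carbonyl group had not been touched by the earlier compounds, which varied only the methoxy pattern, and here it takes a far larger substituent: hydroxy to 3-phenylpropoxy, adding 9 heavy atoms and a six-membered aromatic ring, gives a number 4 percentage points lower from compound 2 to compound 4 (within the scatter) in this assay. This second site therefore behaves like the methoxy positions, since neither the loss of the hydrogen nor the added 3-phenylpropyl chain separates compound 4 from compound 2 on this read-out. Nothing available offers an explanation for this result.

Going by these compounds, whether a methyl or ethyl group on this oxygen, or an amine taking its place to give an amide, would read any differently remains open. With a single concentration and all four compounds within the scatter of one another, the compounds shown also do not reveal which parts of the structure this read-out depends on.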